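A few compounds are considered here, and "the series" means these few. Any claim that something is new, unique, unknown or untested is made for them only; others in the source may bear on it.

In a functional assay on the whole organism for inhibition, with Rattus norvegicus as the target (on this read-out higher numbers stand for an effect only at larger amounts of compound and lower numbers for an effect already at smaller amounts), compound 1, `CC1CC/C(=N\Nc2ccc(F)cc2)c2ncc(C(=O)O)c(=O)n21`, gives only a limit of the assay, > 1000 umol/kg, and not a measured number. Compound 2, `CC1CC/C(=N\Nc2ccccc2I)c2ncc(C(=O)O)c(=O)n21`, carries 2-iodophenyl in place of 4-fluorophenyl on an amine nitrogen. In this assay compound 2 also gives only a limit, > 1000 umol/kg. The step from compound 1 to compound 2 is therefore a step that the two limits leave unreadable from compound 1 to compound 2, because the limit of > 1000 umol/kg in this assay, at which 2 of the 2 values shown sit, holds both ends of it. Compound 3, `CCOc1ccc(N/N=C2\CCC(C)n3c2ncc(C(=O)O)c3=O)cc1`, has not yet been measured; it differs from compound 1 by ethoxy in place of fluoro on an aromatic carbon. Among the compounds with values here, no measured step touches this particular change, and the only step that exists cannot be read at all. Compound 3 is therefore expected to give about 1500 umol/kg, with a range from 500 umol/kg to 5000 umol/kg, and most likely again only a limit rather than a number. The step from compound 1 to compound 3 that this estimate means is expected to be a step that the limit leaves unreadable from compound 1 to compound 3, with nothing in the data pointing toward a stronger effect.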

Compound 3, dose for 50% inhibition: > 100 umol/kg
Compound 3: only a limit was reported; the forecaster's own chance of this, stated with the estimate: 75%; the middle value lies beyond the limit too.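

In this assay compound 3 gives only a limit, > 100 umol/kg, and not a measured number. Compound 1 also gives only a limit, so the step between compound 1 and compound 3 cannot be read. The compounds shown leave open what dose of any of them gives half inhibition, and whether ethoxy and fluoro differ at all.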